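This account rests on a few compounds, and the source may have more. Where it says the series, first, only, none or still open, it means among the compounds named here.

Compound 1 `O=S(=O)(c1ccc2ccccc2c1)N(CCCN1CCN(c2ccccc2)CC1)CC1CCCCC1` gives 1240 nM in an assay on CHO cells for displacement of a labelled ligand from 5-hydroxytryptamine receptor 7 (Homo sapiens); on this read-out higher numbers stand for weaker inhibition and lower numbers for stronger inhibition. Compound 2 `COc1ccccc1N1CCN(CCCN(CC2CCCCC2)S(=O)(=O)c2ccc3ccccc3c2)CC1` gives 500 nM. Compound 3 `O=S(=O)(c1ccc2ccccc2c1)N(CCCN1CCN(c2ccc(F)cc2)CC1)CC1CCCCC1` gives 1510 nM.

Compound 2 holds the lowest of the three numbers in this assay, set apart from both others by a 2.5-fold lower number from compound 1 to compound 2 (0.39 log units; beyond the scatter) and a 3.0-fold higher number from compound 2 to compound 3 (0.48 log units; beyond the scatter), whereas a 1.2-fold higher number from compound 1 to compound 3 (0.09 log units; within the scatter). Compound 4 `COc1ccccc1N1CCN(CCCN(CC2CCCCC2)S(=O)(=O)c2cccc3cccnc23)CC1` differs from compound 2 by quinolin-8-yl in place of naphthalen-2-yl on a sulfonyl sulfur. Going by the values given here, every measured step here alters the group on the amine nitrogen in the ring; none touches the group on the sulfonyl sulfur, so no measured step bears on this change and no direction can be read from the data. The expectation for compound 4 is therefore no change at the digits printed from compound 2 to compound 4 (within the scatter), with a wide range. Compound 4 is estimated at 500 nM, between 150 nM and 1700 nM.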

Compound 4, half-maximal inhibitory concentration: 24 nM
For compound 4 the middle estimate is 21-fold (1.32 log units) above the measured one; the measured number lies below the stated range.
By their numbers in this assay, from the lowest: compound 4; then compound 2; then compounds 1 and 3 (each within the scatter of the next).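

In this assay the group on the sulfonyl sulfur emerges as a strong lever: quinolin-8-yl in place of naphthalen-2-yl gives a 21-fold lower number from compound 2 to compound 4 (1.32 log units; beyond the scatter) and outstrips both a 2.5-fold lower number from compound 1 to compound 2 (0.39 log units; beyond the scatter) and a 3.0-fold higher number from compound 2 to compound 3 (0.48 log units; beyond the scatter) in the group on the amine nitrogen in the ring. The two groups have equal heavy-atom counts, differing by one ring nitrogen in place of carbon. No evidence is available to explain the step. Open, on these data alone, is whether naphthalen-1-yl or plain phenyl on the sulfonyl sulfur would come nearer compound 2 or compound 4, and whether the step holds with phenyl on the amine nitrogen in the ring.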